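Moving the Methoxy Groups on the Sulfonyl Aryl Ring

The source may hold more compounds than are shown below. What is called first, only, known or untested is meant among the compounds shown, and "the series" means these compounds.

Compound 1 `COc1ccc(S(=O)(=O)N(C)c2ccc3[nH]c(-c4n[nH]c5ccccc45)cc3n2)cc1OC` gives 16700 nM in a functional assay on HCT-116 cells (Homo sapiens) for antiproliferative activity, read by MTT assay, with a stated time of 72 h; a lower number here means a stronger inhibitor, a higher number a weaker inhibitor.
Compound 2 `COc1ccc(OC)c(S(=O)(=O)N(C)c2ccc3[nH]c(-c4n[nH]c5ccccc45)cc3n2)c1` gives 8400 nM in this assay.

Compound 2 stands together with compound 1 on these two numbers, since a 2.0-fold lower number from compound 1 to compound 2 (0.30 log units; within the scatter). Compound 3 `COc1ccc(S(=O)(=O)N(C)c2ccc3[nH]c(-c4n[nH]c5ccccc45)cc3n2)c(OC)c1` differs from compound 2 in one place: 2,4-dimethoxyphenyl in place of 2,5-dimethoxyphenyl on a sulfonyl sulfur. Among the measured compounds shown here, the only measured step that bears on this change is the earlier rearrangement of the two methoxy groups, a 2.0-fold lower number from compound 1 to compound 2 (0.30 log units; within the scatter), which stayed within the scatter. On that basis no step beyond the scatter is expected in this assay for the new arrangement. Compound 3 is therefore estimated to give 10000 nM, with a range from 4000 nM to 25000 nM, an expected step of a 1.2-fold higher number from compound 2 to compound 3 (0.08 log units; within the scatter).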

Compound 3, half-maximal inhibitory concentration: 21800 nM
Compound 3: the middle estimate sits 2.2-fold (0.34 log units) below what was measured; low and high end bracket the measured number.
By their numbers in this assay, from the lowest: compounds 2, 1 and 3 (each within the scatter of the next, the first and the last beyond it).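

Among the compounds shown here, the position on the sulfonyl sulfur is not wholly indifferent to where the methoxy groups sit: in this assay there is a 2.6-fold higher number from compound 2 to compound 3 (0.41 log units; beyond the scatter), the first step in this set beyond the scatter, though a modest one. The same 2,4-dimethoxyphenyl compound shows a 1.3-fold higher number from compound 1 to compound 3 (0.12 log units; within the scatter), so the 3,4-dimethoxyphenyl compound remains within the scatter of both others. No evidence is available that accounts for this difference. Still open, on these data alone, is how this position responds to a different substituent, such as an amine or a carboxylic acid, in place of a methoxy group.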